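This account rests on a few compounds, and the source may have more. Where it says the series, first, only, none or still open, it means among the compounds named here.

Compound 1 `Oc1cccc(CNc2ncnc3c2ncn3C2CCCCO2)c1` gives 81000 nM in an ADME assay on K562 cells (Homo sapiens) for cytotoxicity, with a stated time of 72 h; on this read-out lower numbers stand for stronger inhibition and higher numbers for weaker inhibition. Compound 2 `COc1cccc(CNc2ncnc3c2ncn3C2CCCCO2)c1` gives 61000 nM in this assay; the change between them is methyl in place of hydrogen on an oxygen on an aromatic ring, and the step is a 1.3-fold lower number from compound 1 to compound 2 (0.12 log units; within the scatter). Compound 3 `COc1cc(CNc2ncnc3c2ncn3C2CCCCO2)ccc1O` reaches only a limit of the assay in this assay, > 100000 nM. The step from compound 2 is an at least 1.6-fold higher number from compound 2 to compound 3 (0.21 log units; that floor lies within the scatter); the difference between the core of compound 1 and the core of compound 3 is not broken down here. Compound 4 `COc1ccc(CNc2ncnc3c2ncn3C2CCCCO2)cc1OC` differs from compound 3 by methyl in place of hydrogen on an oxygen on an aromatic ring, the same change as from compound 1 to compound 2. That earlier step was a 1.3-fold lower number from compound 1 to compound 2 (0.12 log units; within the scatter), while compound 3 sits at the limit of > 100000 nM in this assay, at which 1 of the 3 values shown sits. A similarly small step is therefore expected for compound 4, namely an at least 1.1-fold lower number from compound 3 to compound 4 (0.04 log units; that floor lies within the scatter). Compound 4 is estimated at 90000 nM in this assay, between 45000 nM and 180000 nM.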

Compound 4, half-maximal inhibitory concentration: > 100000 nM
Compound 4: only a limit was reported (the forecaster's own chance of this, stated with the estimate: 45%); at least 1.1-fold (0.04 log units) between middle value and limit.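

Compound 3 and compound 4 both sit at a limit of the assay, not at a number: the limit of > 100000 nM in this assay, at which 2 of the 4 values shown sit. The step between them therefore cannot be read, so the change from hydroxy to methoxy has only one readable size in this series, a 1.3-fold lower number from compound 1 to compound 2 (0.12 log units; within the scatter), and nothing shows whether that size carries over to the core of compound 3. Among the compounds shown here, the one new step that can be read, an at least 1.6-fold higher number from compound 2 to compound 4 (0.21 log units; that floor lies within the scatter), belongs to a different change, one that adds a methoxy group to an aromatic carbon, and gives only a floor.

The compounds shown leave open whether any change on this aromatic ring would give a number rather than a limit in this assay. From the compounds shown here alone, how an amine or a carboxylic acid would read in place of the hydroxy group also stays open.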